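Swapping methylcarbamoyl for methylsulfonyl on the amide-type nitrogen

The compounds below may be only part of what the source reports. "The series", "measured", "known", "first", "only" and "open" are said of these compounds alone.

Three compounds share one core and differ in the group on a carbonyl carbon. In a functional assay on blood (Homo sapiens), with a stated time of 60 min, in the presence of a further agent that is not named here (a higher number here means that more compound is needed for the effect, a lower number that less compound is needed), compound 1 `O=C(Oc1ccccc1)C1(S(=O)(=O)c2ccc(Oc3ccc(OC(F)(F)F)cc3)cc2)CCC2(CCNCC2)C1` gives 900 nM. Compound 2 `O=C(Nc1ccccn1)C1(S(=O)(=O)c2ccc(Oc3ccc(OC(F)(F)F)cc3)cc2)CCC2(CCNCC2)C1` reads > 15000 nM, which is a limit of the assay and not a number. Compound 3 `CNC(=O)NC(=O)C1(S(=O)(=O)c2ccc(Oc3ccc(OC(F)(F)F)cc3)cc2)CCC2(CCNCC2)C1` reads < 400 nM, also a limit, and it is the lowest reading of the three.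

Compound 4 `CS(=O)(=O)NC(=O)C1(S(=O)(=O)c2ccc(Oc3ccc(OC(F)(F)F)cc3)cc2)CCC2(CCNCC2)C1` is compound 3 with methylsulfonyl in place of methylcarbamoyl on the amide-type nitrogen (methylsulfonyl in place of methylcarbamoyl on an amide-type nitrogen). Among the measured compounds shown here, no measured step introduces methylsulfonyl, so the evidence is indirect. The closest step, at the same nitrogen, is an at least 37-fold lower number from compound 2 to compound 3 (1.57 log units; beyond the scatter), and it is large. The step of an at least 2.2-fold lower number from compound 1 to compound 3 (0.35 log units; beyond the scatter) is at least modest. Methylsulfonyl, like the methylcarbamoyl of compound 3 at < 400 nM, carries no ring, so compound 4 is expected to stay close to it. The estimated step of a number no lower from compound 3 to compound 4 (the limit leaves the size open) is expected to lie within the scatter, with no clear direction. For compound 4 the expected value is 400 nM, with an estimated range from 120 nM to 1500 nM.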

Compound 4, half-maximal effective concentration: > 15000 nM
Compound 4: a limit, no number; the forecaster's own chance of this, stated with the estimate: 40%; middle value at least 37-fold (1.57 log units) away from the limit.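

In this assay, the change on this amide-type nitrogen gives an at least 37-fold higher number from compound 3 to compound 4 (1.57 log units; beyond the scatter), even though methylcarbamoyl and methylsulfonyl both carry no ring and have equal numbers of heavy atoms. Compound 4 reads at a limit of the assay, not a number, and compound 2 reads at the same limit, so a high reading on this nitrogen does not require a ring, and the step between these two cannot be read: the limit of > 15000 nM in this assay, at which 2 of the 4 values shown sit. Methanesulfonamido on the carbonyl carbon also compares poorly with phenoxy there, with an at least 16-fold higher number from compound 1 to compound 4 (1.22 log units; beyond the scatter).

The compounds shown leave open whether the hydrogen-bond donor counted in methylcarbamoyl matters, or some other feature of that group. Dimethylcarbamoyl on the same nitrogen, which keeps the carbonyl but has no such hydrogen, would help separate these possibilities.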